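The source may hold more compounds than are shown below. What is called first, only, known or untested is meant among the compounds shown, and "the series" means these compounds.

Measured so far:
compound 1 `O=C(CCCl)Nc1ccc(I)cc1` gives 18000 nM
compound 2 `CC(C)(C)c1ccc(NC(=O)CCCl)cc1` gives 88000 nM
compound 3 `CC(C)(C)c1ccc(CNC(=O)CCCCl)cc1` gives 72000 nM

In a functional assay on HT-29 cells (Homo sapiens) for antiproliferative activity, with a stated time of 48 h (a lower number here means a stronger inhibitor, a higher number a weaker inhibitor), compound 2 has the highest number of the three. Compound 3 is near it, within the scatter, while compound 1 sits well apart: a 4.9-fold higher number from compound 1 to compound 2 (0.69 log units; beyond the scatter). Compound 4 `C=CC(=O)Nc1ccc(C(C)(C)C)cc1` arises from compound 2 by vinyl in place of 2-chloroethyl on a carbonyl carbon. Within the data shown here, no measured step touches this part of the molecule; the only step beyond the scatter concerns the aromatic substituent, and compounds 2 and 3 differ in two places, so their values can only be set side by side. Compound 4 is therefore estimated with little guidance, and a change of a 2.2-fold lower number from compound 2 to compound 4 (0.34 log units; beyond the scatter) is expected, with wide bounds. Compound 4 is expected to give 40000 nM, between 10000 nM and 150000 nM.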

Compound 4, half-maximal inhibitory concentration: 24000 nM
Compound 4: the middle estimate sits 1.7-fold (0.22 log units) above what was measured; the range from low to high includes it.
By their numbers in this assay, from the lowest: compounds 1 and 4 (each within the scatter of the next); then compounds 3 and 2 (each within the scatter of the next).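

In this assay, the group on a carbonyl carbon whose other neighbour is the amide-type nitrogen proves able to move the number: vinyl in place of 2-chloroethyl gives a 3.7-fold lower number from compound 2 to compound 4 (0.56 log units; beyond the scatter) and is a step beyond the scatter. Before this, the only such step concerned the aromatic substituent. No evidence at hand accounts for the change. On these data alone, whether a longer chain or an amine on this carbonyl carbon would give a similar number remains open. So does whether the same exchange would have a similar effect with iodo in place of tert-butyl.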